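Methoxy in Place of Chloro: A Growth Inhibition Estimate

The source may hold more compounds than are shown below. What is called first, only, known or untested is meant among the compounds shown, and "the series" means these compounds.

Compound 1 `COc1cc(/C=C/C(=O)c2cccc(-n3cc(-c4ccc(Cl)cc4)[nH]c3=O)c2)cc(OC)c1OC`: in a functional assay on HOP-92 cells (Homo sapiens) for inhibition (a higher number here means a weaker inhibitor of growth, a lower number a stronger inhibitor of growth), compound 1 gives "not active" (no number reported), with no number.
Compound 2 `COc1cc(/C=C/C(=O)c2cccc(-n3cc(-c4ccccc4)[nH]c3=O)c2)ccc1O`: in this assay compound 2 gives 2270 nM.

Compound 1 stands without any number on this scale; it is only recorded as not active. Compound 3 `COc1ccc(-c2cn(-c3cccc(C(=O)/C=C/c4cc(OC)c(OC)c(OC)c4)c3)c(=O)[nH]2)cc1` differs from compound 1 in one place: methoxy in place of chloro on an aromatic carbon. For the measured compounds named here, no step between two measured compounds is available, so the size of this change cannot be read from the data, and compound 2, which differs at several places, offers no direct guide. The expectation is that compound 3 stays weak, with a real chance that only a limit is reported, and its estimated value in this assay is 10000 nM (range 2500 nM to 50000 nM).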

Compound 3, concentration for 50% growth inhibition: 14900 nM
The estimate for compound 3 lay 1.5-fold (0.17 log units) below the measured number, within the range that was stated.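

In this assay, for the compounds shown here, compound 1 gives "not active" (no number reported) and so offers no number, which means no step to compound 3 can be read. What replacing chloro with methoxy does to growth inhibition stays open, and no measurement shown here offers an explanation.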